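A few compounds are considered here, and "the series" means these few. Any claim that something is new, unique, unknown or untested is made for them only; others in the source may bear on it.

The series shares the core of compound 1 `CCNCc1cn(Cc2ccccc2)c2ccccc12`. Going by the values given here, in an assay on isolated protein for inhibition of Amine oxidase [flavin-containing] A (Rattus norvegicus) (a higher number here means a weaker inhibitor, a lower number a stronger inhibitor), compound 1 gives 262000 nM, the highest of the two numbers measured so far. Among the compounds with values here, compound 2 `Cn1c(CNCc2ccccc2)cc2ccccc21` gives 34000 nM in this assay, a lower number, and the gap between the two lies beyond the scatter; no single-point step connects them, so their two values stand on their own. Next in line is compound 3 `C#CCN(C)Cc1cn(Cc2ccccc2)c2ccccc12`, which changes compound 1 in one place: methyl(propargyl)amino in place of ethylamino on a saturated chain carbon bound to an aromatic carbon. Within the data shown here, no step between measured compounds speaks to a change of this kind, so its size can only be expected, not read off. The expectation is a drop in the number, by a step of about a 17-fold lower number from compound 1 to compound 3 (1.24 log units; beyond the scatter) in this assay, given that compound 1 starts from 262000 nM and so has room to move downward. Compound 3 is accordingly estimated at 15000 nM in this assay, with a range from 1500 nM to 150000 nM. Among the measured compounds shown here, the range is deliberately wide, as the series offers no measured step to lean on.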

Compound 3, inhibition constant: 160000 nM
For compound 3 the middle estimate is 11-fold (1.03 log units) below the measured one, and the stated range ends below it.
By their numbers in this assay, from the lowest: compound 2; then compounds 3 and 1 (each within the scatter of the next).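

In this assay, the step to methyl(propargyl)amino in place of ethylamino on a saturated chain carbon bound to an aromatic carbon reads a 1.6-fold lower number from compound 1 to compound 3 (0.21 log units; within the scatter), so the two compounds cannot be told apart at this place. Going by these compounds alone, this is the first single-point step, and it shows that the exchange, which removes the hydrogen-bond donor of ethylamino and brings in a triple bond outside aromatic rings, leaves no effect that can be read beyond the scatter in this assay. Nothing on hand bears on why the two values lie so close.

The compounds shown leave open whether methylamino or propargylamino alone at this place would read differently from the two groups compared here, so the contributions of the methyl and the propargyl parts to the step remain unseparated. Also open, from the compounds shown here alone, is whether a longer chain on the nitrogen, such as propylamino, or a cyclic amine such as piperidine would move the number beyond the scatter.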